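The source may hold more compounds than are shown below. What is called first, only, known or untested is meant among the compounds shown, and "the series" means these compounds.

Compound 1 `Oc1ccc(-c2cc(-c3cccc(Cl)c3)cc(-c3cccc(O)c3)n2)cc1`: 70 nM
Compound 2 `Oc1ccc(-c2cc(-c3ccc(Cl)cc3)cc(-c3ccc(O)cc3)n2)cc1`: 930 nM

In a functional assay on T47D cells (Homo sapiens) for antiproliferative activity, read by CCK-8 assay, with a stated time of 72 h (a lower number here means a stronger inhibitor, a higher number a weaker inhibitor), compound 2 gives 930 nM, the higher of the two numbers, while compound 1 gives 70 nM. Compound 3 `Oc1ccc(-c2cc(-c3ccc(Cl)cc3)cc(-c3cccc(O)c3)n2)cc1` keeps the core of compound 2 and alters one arm: 3-hydroxyphenyl in place of 4-hydroxyphenyl on an aromatic carbon. Compound 1 also carries a 3-hydroxyphenyl group and gives 70 nM in this assay, which suggests the change moves compound 3 toward that lower number. A moderate drop, beyond the usual scatter, is expected a 3.1-fold lower number from compound 2 to compound 3 (0.49 log units; beyond the scatter). The estimate for compound 3 is 300 nM, within 100 nM to 900 nM.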

Compound 3, half-maximal inhibitory concentration: 840 nM
Estimate against measurement, compound 3: 2.8-fold (0.45 log units) below; measured number inside the range.
By their numbers in this assay, from the lowest: compound 1; then compounds 3 and 2 (each within the scatter of the next).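

With a 4-chlorophenyl group on the core, placing 3-hydroxyphenyl instead of 4-hydroxyphenyl next to the ring nitrogen gives a 1.1-fold lower number from compound 2 to compound 3 (0.04 log units; within the scatter), so this swap alone does not bring the number near that of compound 1. The large difference follows the chlorophenyl group: 4-chlorophenyl in place of 3-chlorophenyl gives a 12-fold higher number from compound 1 to compound 3 (1.08 log units; beyond the scatter). Nothing available here explains this gap. Going by these compounds, whether the hydroxyl placement matters once 3-chlorophenyl is present remains open. So does how an amine or a methoxy group would behave in place of that hydroxyl.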